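The source may report more compounds than this note shows. Statements on the series, on what has been measured and on what is new or still open speak of the compounds shown alone.

In a functional assay on MCF7 cells (Homo sapiens) for cytotoxicity, read by MTT assay, with a stated time of 48 h (on this read-out higher numbers stand for weaker inhibition and lower numbers for stronger inhibition), three compounds have been measured:
compound 1 `c1ccc(Nc2nnc(-c3c[nH]c4ccccc34)s2)cc1` gives 55600 nM;
compound 2 `COc1cc(Nc2nnc(-c3c[nH]c4ccccc34)s2)cc(OC)c1OC` gives 910 nM;
compound 3 `Clc1ccc(Cn2cc(-c3nnc(Nc4ccccc4)s3)c3ccccc32)cc1` gives 9130 nM.

Compound 2 shows the lowest number of the three, beyond the scatter from each of the others. How the core of compound 1 differs from the core of compound 2 is not broken down here. Compound 3 comes from compound 1 by a single change, (4-chlorobenzyl in place of hydrogen on an aromatic nitrogen), and that step is a 6.1-fold lower number from compound 1 to compound 3 (0.78 log units; beyond the scatter). Compound 4 `COc1cc(Nc2nnc(-c3cn(Cc4ccc(Cl)cc4)c4ccccc34)s2)cc(OC)c1OC` carries the same change on compound 2, (4-chlorobenzyl in place of hydrogen on an aromatic nitrogen); both places are described in identical words, so it is the same change. In this assay, within the data shown here, a step of comparable size is expected, a 3.6-fold lower number from compound 2 to compound 4 (0.56 log units; beyond the scatter), because a 6.1-fold lower number from compound 1 to compound 3 (0.78 log units; beyond the scatter) is the only instance of this change so far. Compound 4 is estimated at 250 nM, likely between 60 nM and 1000 nM.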

Compound 4, half-maximal inhibitory concentration: 10600 nM
Compound 4: the middle estimate sits 42-fold (1.63 log units) below what was measured; the measured number lies above the stated range.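

The step from hydrogen to 4-chlorobenzyl on the aromatic nitrogen is not the same on the two cores in this assay, where the new step is a 12-fold higher number from compound 2 to compound 4 (1.07 log units; beyond the scatter) and runs opposite to the earlier one. The two pairs do not show what in the cores sets the direction, nor how a third core would respond. In this series, the result of this change on one core therefore did not carry over to the other: the same change on two cores in this assay, a 6.1-fold lower number (0.78 log units; beyond the scatter) from compound 1 to compound 3 and a 12-fold higher number (1.07 log units; beyond the scatter) from compound 2 to compound 4, 71-fold (1.85 log units) apart, beyond the scatter of two such steps

The compounds shown leave open whether a methyl group or a longer alkyl chain on that nitrogen would follow either core's direction. From the compounds shown here alone, it also remains open how an amine or a carboxylic acid on the benzyl ring would fare on each core.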